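The source may report more compounds than this note shows. Statements on the series, on what has been measured and on what is new or still open speak of the compounds shown alone.

Values in a functional assay on HeLa cells (Homo sapiens) for antiproliferative activity, read by MTT assay, with a stated time of 72 h (a higher number here means a weaker inhibitor, a lower number a stronger inhibitor), follow.

Compound 1 `COc1ncc(-c2ccc3c(c2)N(c2ccc(C)cc2)C(=O)CO3)cc1NS(=O)(=O)c1ccc(F)cc1` gives 4650 nM
Compound 2 `COc1ccc(N2C(=O)COc3ccc(-c4ccc(O)cc4)cc32)cc1` gives 16400 nM
Compound 3 `COc1cccc(N2C(=O)COc3ccc(-c4ccc(O)cc4)cc32)c1` gives > 40000 nM (a limit of the assay, not a number)

On these numbers, compound 3 has no exact value in this assay and stands only at its limit. This is the limit of > 40000 nM in this assay, at which 1 of the 3 values shown sits. Compound 4 (`O=C1COc2ccc(-c3ccc(O)cc3)cc2N1`) has hydrogen in place of 3-methoxyphenyl on an amide-type nitrogen in a ring, a change counted as hydrogen in place of 3-methoxyphenyl on an amide-type nitrogen in a ring. Among the measured compounds shown here, the one measured step at this nitrogen is an at least 2.4-fold higher number from compound 2 to compound 3 (0.38 log units; beyond the scatter) and it only swaps 4-methoxyphenyl for 3-methoxyphenyl, so it gives no direct size for losing the whole group. No step beyond the scatter is expected in either direction.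

The estimated step is an at least 1.0-fold lower number from compound 3 to compound 4 (0.02 log units; that floor lies within the scatter). Compound 4 is expected at 38000 nM, with an estimated range of 14000 nM to 90000 nM.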

Compound 4, half-maximal inhibitory concentration: > 40000 nM
Compound 4 gave a limit, no number; the forecaster's own chance of this, stated with the estimate: 50%; middle value at least 1.0-fold (0.02 log units) from the limit.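

In this assay, putting hydrogen in place of the 4-methoxyphenyl group on the amide-type nitrogen gives an at least 2.4-fold higher number from compound 2 to compound 4 (0.38 log units; beyond the scatter). Among the compounds with this shared core, a group on this nitrogen can therefore matter, yet having an aromatic ring there is not enough, since the 3-methoxyphenyl group of compound 3 also fails to give a number. Compound 3 and compound 4 each stand at a limit of the assay, not at a number, so the step between them cannot be read: the limit of > 40000 nM in this assay, at which 2 of the 4 values shown sit.

Still open, on these data alone, is whether a small methyl group or a benzyl group on this nitrogen would give a measurable value.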